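The compounds below may be only part of what the source reports. "The series", "measured", "known", "first", "only" and "open" are said of these compounds alone.

Values measured so far in a functional assay on HCT-116 cells (Homo sapiens) for antiproliferative activity; a lower number here means a stronger inhibitor of growth, a higher number a weaker inhibitor of growth:

- compound 1 `CCCCCCNC(=O)c1cc(C#Cc2cc(OC)ccc2OC)ccc1OC` gives 6900 nM 
- compound 2 `CCCCCCNC(=O)c1cc(/C=C\c2cc(O)ccc2O)ccc1O` gives 3900 nM 

Among the compounds with values here, compound 1 at 6900 nM and compound 2 at 3900 nM lie within the usual scatter of each other, so compound 1 stands level with the only other measured compound. Compound 3 `COc1ccc(OC)c(C#Cc2ccc(OC)c(C(=O)O)c2)c1` has not yet been measured in this assay. It keeps the core of compound 1 and differs in one place, with hydroxy in place of hexylamino on a carbonyl carbon and the hexylcarbamoyl thus becoming carboxy. Within the data shown here, no measured pair shows this change on its own, so the data give no direct guide to its size. Both measured compounds carry the hexylamino group, and none lacks it. The expectation is therefore a judgement: a move to a higher number, meaning a weaker inhibitor of growth, beyond the scatter, with the estimated step of a 3.6-fold higher number from compound 1 to compound 3 (0.56 log units; beyond the scatter) as its expected size. Compound 3 is expected at 25000 nM with an estimated range from 8000 nM to 80000 nM in this measurement.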

Compound 3, concentration for 50% growth inhibition: 32300 nM
For compound 3 the middle estimate is 1.3-fold (0.11 log units) below the measured one; the range from low to high includes it.
By their numbers in this assay, from the lowest: compounds 2 and 1 (each within the scatter of the next); then compound 3.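

In this assay, within the data shown here, the exchange of hexylcarbamoyl for carboxy, with hydroxy in place of hexylamino on a carbonyl carbon, produces a 4.7-fold higher number from compound 1 to compound 3 (0.67 log units; beyond the scatter), and this is the first step to lie beyond the scatter. It shows that this position is not indifferent: with the rest of the core of compound 1 unchanged, the group on the carbonyl carbon moves the number, and of this pair the compound carrying hexylamino is the stronger inhibitor of growth. No measurement available here bears on why the number rises.

This single pair cannot separate the loss of the hexyl chain from the arrival of hydroxy, since the two happen in one change. The compounds shown leave open whether a shorter chain such as butylamino, a longer chain such as octylamino, or a methoxy group in the same place on the carbonyl carbon would stay near compound 1 or near compound 3 in this assay.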